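Replacing the Chlorophenyl with a Piperidine: What to Expect

The source may report more compounds than this note shows. Statements on the series, on what has been measured and on what is new or still open speak of the compounds shown alone.

Of the compounds shown here, three sharing one core have been tested in a functional assay on PC-3 cells (Homo sapiens) for antiproliferative activity, read by MTT assay, with a stated time of 24 h; on this read-out lower numbers stand for stronger inhibition and higher numbers for weaker inhibition. Compound 1 `COc1ccc(-c2noc(-c3ccccc3)n2)cc1OC1CCCC1` reaches only the limit of the assay, > 1000000 nM, in this assay. Compound 2 `COc1ccc(-c2noc(-c3ccc(Cl)cc3)n2)cc1OC1CCCC1` likewise gives only a limit, > 1000000 nM. Compound 3 `COc1ccc(-c2noc(Cc3c[nH]c4ccccc34)n2)cc1OC1CCCC1` also gives only a limit, > 1000000 nM. Going by the values given here, the one step between neighbours, a step that the two limits leave unreadable from compound 1 to compound 2, cannot be read in size, since both of its ends are limits. Compound 2 therefore stands at the same limit as its two companions, with no number that ranks it against them; all three sit at the limit of > 1000000 nM in this assay, at which 3 of the 3 values shown sit.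

Compound 4 `COc1ccc(-c2noc(C3CCNCC3)n2)cc1OC1CCCC1` has not yet been measured in this assay. It differs from compound 2 by piperidin-4-yl in place of 4-chlorophenyl on an aromatic carbon. No measured step mirrors this change, and the single step shown, from compound 1 to compound 2, was unreadable, so nothing in the present data sets a direction or a size for the step to compound 4. Given that every value so far is a limit, compound 4 is expected to give about 1000000 nM in this assay, within 200000 nM to 5000000 nM, most likely again reported only as a limit. The expected step is therefore a number no higher from compound 2 to compound 4 (the limit leaves the size open), which is to say no readable change.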

Compound 4, half-maximal inhibitory concentration: > 1000000 nM
Compound 4 ended at the assay's limit; the forecaster's own chance of this, stated with the estimate: 75%; the middle value lies on the limit itself.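

No step can be read from compound 1 or compound 2 to compound 4, as both ends of each pair are limits of this assay. All the compounds shown stand together: the limit of > 1000000 nM in this assay, at which 4 of the 4 values shown sit.

What they leave open is whether any compound on the shared core gives a measurable value in this assay, and which change would bring one about.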